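Replacing the Hydroxyphenyl of Compound 3 with Chlorophenyl

This account rests on a few compounds, and the source may have more. Where it says the series, first, only, none or still open, it means among the compounds named here.

Compound 3 `Cc1cccc2c1N(CC(=O)O)C/C(=C\c1cccc(O)c1)C2=O` stands highest of the three compounds measured in an assay on HL-60 cells for inhibition of glutathione S-transferase P (Homo sapiens), read by spectrophotometry, tested at 20 uM (on this read-out lower numbers stand for less inhibition and higher numbers for more inhibition at the one concentration tested (going by the name of the read-out)), where compound 3 gives 75.6%. Compound 1 `Cc1cccc2c1N(CC(=O)O)C/C(=C\c1ccc(F)cc1)C2=O` gives 22.9% and compound 2 `CCOc1ccccc1/C=C1\CN(CC(=O)O)c2c(C)cccc2C1=O` gives 15.4%, both far lower. Compound 4 `Cc1cccc2c1N(CC(=O)O)C/C(=C\c1ccccc1Cl)C2=O` differs from compound 3 in one place: 2-chlorophenyl in place of 3-hydroxyphenyl on a double-bonded chain carbon bound to a double-bonded ring carbon. Within the data shown here, the one measured step bearing on this change is a number 52.7 percentage points higher from compound 1 to compound 3 (beyond the scatter), where a hydroxyphenyl entered; compound 4 goes the other way, the hydroxyphenyl leaving and a chlorophenyl entering. The two compounds without the hydroxyl, compound 1 and compound 2, both sit low. A large drop is therefore expected, a number 55.6 percentage points lower from compound 3 to compound 4 (beyond the scatter). For compound 4 the estimate is 20%, with a range from 5% to 40%.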

Compound 4, a percentage reported as inhibition, at one concentration (the size of the read-out at that concentration, not a potency): 51.9%
For compound 4 the middle estimate is 31.9 percentage points below the measured one, outside the stated range (above it).
By their numbers in this assay, from the lowest: compounds 2 and 1 (each within the scatter of the next); then compound 4; then compound 3.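

In this assay, a high reading at this place does not depend on the hydroxyl alone: the change gives a number 23.7 percentage points lower from compound 3 to compound 4 (beyond the scatter), a modest step. The 2-chlorophenyl also reads well over the other groups without a hydroxyl, with a number 29 percentage points higher from compound 1 to compound 4 (beyond the scatter) and a number 36.5 percentage points higher from compound 2 to compound 4 (beyond the scatter). Nothing available explains these differences. The 2-chlorophenyl and 3-hydroxyphenyl differ in both the group and its ring number, and these compounds cannot separate the two. Going by these compounds, how a 3-chlorophenyl or a 3-aminophenyl would read remains open.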